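A few compounds are considered here, and "the series" means these few. Any claim that something is new, unique, unknown or untested is made for them only; others in the source may bear on it.

Compound 1, with the structure `CC(C)=CCC/C(C)=C/CC/C(C)=C/CC[C@@H]1[C@@]2(C)CCC(=O)C(C)(C)[C@@H]2CC[C@@]1(C)O`, is the simplest member of this small set. In a functional assay on HeLa cells (Homo sapiens) for cytotoxicity, read by MTT assay, with a stated time of 48 h (on this read-out lower numbers stand for stronger inhibition and higher numbers for weaker inhibition), compound 1 gives 18300 nM. Compound 2, with the structure `CC(C)=CCC/C(C)=C/CC/C(C)=C/CC[C@@H]1[C@@]2(C)CC/C(=N\OCc3cn(-c4cccc(Br)c4)nn3)C(C)(C)[C@@H]2CC[C@@]1(C)O`, carries a 3-bromophenyl on the five-membered aromatic ring with 3 nitrogen; in this assay compound 2 gives 15700 nM. That is the lowest of the two numbers recorded, but its nearest neighbour, compound 1, lies within the scatter of it, so the two values show no real separation.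

Compound 3, with the structure `CC(C)=CCC/C(C)=C/CC/C(C)=C/CC[C@@H]1[C@@]2(C)CC/C(=N\OCc3cn(-c4c(Cl)cc([N+](=O)[O-])cc4Cl)nn3)C(C)(C)[C@@H]2CC[C@@]1(C)O`, is the next compound to be measured. It differs from compound 2 in one place: 2,6-dichloro-4-nitrophenyl in place of 3-bromophenyl on an aromatic nitrogen. Going by the values given here, no step between two measured compounds is available that would show what this kind of exchange does on the shared core, and the one comparison on hand, between compound 1 and compound 2, shows no change beyond the scatter.

With nothing in the measured pairs pointing either way, the step from compound 2 to compound 3 is expected to be a 1.1-fold lower number from compound 2 to compound 3 (0.05 log units; within the scatter), that is, no more than the scatter. Compound 3 is therefore estimated to give 14000 nM in this assay, within a range of 6000 nM to 30000 nM.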

Compound 3, half-maximal inhibitory concentration: 23000 nM
For compound 3 the middle estimate is 1.6-fold (0.22 log units) below the measured one, and the stated range covers the measured number.
By their numbers in this assay, from the lowest: compounds 2, 1 and 3 (each within the scatter of the next).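

In this assay, 2,6-dichloro-4-nitrophenyl in place of 3-bromophenyl on an aromatic nitrogen of the five-membered aromatic ring with 3 nitrogen gives a 1.5-fold higher number from compound 2 to compound 3 (0.17 log units; within the scatter). Going by these compounds alone, this is the first direct reading at this position, and it shows that a group of 11 heavy atoms with 2 hydrogen-bond acceptors can replace one of 7 heavy atoms with 0 hydrogen-bond acceptors without a step beyond the scatter. Nothing available here speaks to the reason for this result.

The exchange replaces the bromine and brings in both chlorines and the nitro group at once, so the share of each cannot be read, and a phenyl carrying only a nitro group or only chlorine would be needed to separate them. Both groups shown at this position are halogen-bearing phenyl rings, which leaves open whether the numbers would stay level with a phenyl carrying an amine or a carboxylic acid, or with a plain alkyl chain on the same nitrogen.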